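Cytotoxicity notes: ether side-chain variation on a shared core

The compounds below may be only part of what the source reports. "The series", "measured", "known", "first", "only" and "open" are said of these compounds alone.

Measured in a functional assay on CCRF-CEM cells (Homo sapiens) for cytotoxicity; on this read-out lower numbers stand for higher toxicity in this test and higher numbers for lower toxicity in this test:
- compound 1 `O=C1c2ccccc2NS(=O)(=O)N1COCCO`: > 200 ug/mL
- compound 2 `O=C1c2ccccc2N(Cc2ccccc2)S(=O)(=O)N1COCc1ccccc1`: 100 ug/mL
- compound 3 `C#CCOCN1C(=O)c2ccccc2NS1(=O)=O`: > 200 ug/mL

For compound 3 the value in this assay is a limit of the assay, not a number. Compound 1 likewise returns only a limit. Together the two readings give a step that the two limits leave unreadable from compound 1 to compound 3. Compound 3 therefore stands at the limit of > 200 ug/mL in this assay, at which 2 of the 3 values shown sit, and nothing more precise can be said about its toxicity. For the measured compounds named here, compound 2, which carries a benzyl on both nitrogens of the core and so differs from the rest in two places, is the only measured compound with a number in this assay.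

Compound 4 `O=C1c2ccccc2NS(=O)(=O)N1COCc1ccccc1` follows from compound 3 by phenyl in place of ethynyl on a saturated chain carbon bound to an oxygen on a saturated carbon, in other words propargyl to benzyl. Going by the values given here, no measured step bears directly on this exchange: the single step available is unreadable, and compound 2 is not connected to compound 4 by any single change. The expectation can rest only on the pattern that both measured single-ether analogues, compound 1 and compound 3, sit at the limit.

For compound 4 the estimate in this assay is 200 ug/mL, with a range from 80 ug/mL to 500 ug/mL. The expected step is a number no higher from compound 3 to compound 4 (the limit leaves the size open), read against a starting value that is itself only a limit.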

Compound 4, half-maximal cytotoxic concentration: 91 ug/mL
The estimate for compound 4 lay 2.2-fold (0.34 log units) above the measured number, within the range that was stated.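

In this assay, phenyl in place of ethynyl on a saturated chain carbon bound to an oxygen on a saturated carbon gives an at least 2.1-fold lower number from compound 3 to compound 4 (0.34 log units; beyond the scatter), the first readable effect of changing this side chain on the shared core. Phenyl in place of hydroxymethyl at the same place gives an at least 2.1-fold lower number from compound 1 to compound 4 (0.34 log units; beyond the scatter), so among the three side chains shown with the sulfonamide nitrogen unsubstituted, only the one carrying phenyl yields a number rather than a limit. Hydrogen in place of benzyl on a sulfonamide nitrogen in a ring gives a 1.1-fold lower number from compound 2 to compound 4 (0.04 log units; within the scatter), which lies within the scatter, so the benzyl on that nitrogen makes no readable difference in this pair, and the number seen for compound 2 is not tied to that group.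

The true size of the two steps beyond the scatter stays open, since each starts from a value that is a limit and not a number: the limit of > 200 ug/mL in this assay, at which 2 of the 4 values shown sit. Whether an amine, a carboxylic acid or a longer chain at this place would also give a number, or whether the aromatic ring of the benzyl group is needed for one, cannot be told from the compounds shown.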